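The compounds below may be only part of what the source reports. "The series", "measured", "known", "first", "only" and "open" are said of these compounds alone.

In a physicochemical assay for solubility, using the shake flask method, with a stated time of 24 h, at pH 1 (on this read-out higher numbers stand for higher solubility and lower numbers for lower solubility), compound 1 `Cc1ccnc(NC(c2ccc([N+](=O)[O-])cc2)c2ccc3cccnc3c2O)c1` gives 1050000 nM. Compound 2 `COc1ccc(C(Nc2ccccn2)c2ccc3cccnc3c2O)cc1` gives 102000 nM in this assay, the lowest of the two numbers; its nearest neighbour, compound 1, stands higher by a gap beyond the scatter. Compound 3 `Oc1c(CNc2ccccn2)ccc2cccnc12` differs from compound 2 by hydrogen in place of 4-methoxyphenyl on a saturated chain carbon bound to an aromatic carbon and a nitrogen on an aromatic ring. Among the compounds with values here, no measured pair shows this change, so the size of the step rests on the change alone. An upward step beyond the scatter is expected, and the estimate means the step of a 3.4-fold higher number from compound 2 to compound 3 (0.54 log units; beyond the scatter). Compound 3 is estimated at 350000 nM in this assay, with a range from 120000 nM to 1200000 nM.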

Compound 3, solubility: 1140000 nM
The estimate for compound 3 lay 3.3-fold (0.51 log units) below the measured number; the measured number falls inside the stated range.
By their numbers in this assay, from the lowest: compound 2; then compounds 1 and 3 (each within the scatter of the next).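

Hydrogen in place of 4-methoxyphenyl on this saturated chain carbon gives an 11-fold higher number from compound 2 to compound 3 (1.05 log units; beyond the scatter) in this assay as the first step read at this position. The position is therefore not silent on this read-out: a change in this one group moves the number by a large step. No measured evidence on hand accounts for the step.

As far as these compounds go, whether the step follows the loss of the whole aromatic ring or of the methoxy group alone remains open. A plain phenyl, a methyl or an amine-bearing chain on the same carbon would separate these readings.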